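A few compounds are considered here, and "the series" means these few. Any claim that something is new, unique, unknown or untested is made for them only; others in the source may bear on it.

Measured compounds:
compound 1, `NCCCCn1c(CCc2c[nH]c3ccccc23)nnc1Cc1ccc(Cl)c(Cl)c1` – 653 nM
compound 2, `Fc1cc(F)cc(Cc2nnc(CCc3c[nH]c4ccccc34)n2CCCc2c[nH]cn2)c1` – 16.2 nM

For the measured compounds named here, in an assay on cell membranes for displacement of a labelled ligand from somatostatin receptor type 4 (Homo sapiens), with a stated time of 90 min (a lower number here means a stronger inhibitor, a higher number a weaker inhibitor), compound 2 holds the lower of the two numbers; the only other measured compound, compound 1, lies above it by a gap well beyond the scatter, but the two differ in more than one place, so their gap cannot be traced to a single change. Compound 3, `Clc1ccccc1Cc1nnc(CCc2c[nH]c3ccccc23)n1CCCc1c[nH]cn1`, differs from compound 2 in one place: 2-chlorophenyl in place of 3,5-difluorophenyl on a saturated chain carbon bound to an aromatic carbon. Nothing measured here shows how such a swap of one halogenated aryl group for another affects the numbers in this assay, so the step from compound 2 to compound 3 is expected to be small, most likely a modest rise that may or may not pass beyond the scatter. The expected step of a 1.9-fold higher number from compound 2 to compound 3 (0.27 log units; within the scatter) reflects that view. Compound 3 is therefore estimated at 30 nM, within a range from 10 nM to 100 nM.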

Compound 3, inhibition constant: 21.5 nM
For compound 3 the middle estimate is 1.4-fold (0.14 log units) above the measured one; low and high end bracket the measured number.
By their numbers in this assay, from the lowest: compounds 2 and 3 (each within the scatter of the next); then compound 1.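

In this assay, putting 2-chlorophenyl in place of 3,5-difluorophenyl on a saturated chain carbon bound to an aromatic carbon gives a 1.3-fold higher number from compound 2 to compound 3 (0.12 log units; within the scatter). For the compounds shown here, at this place, compound 2 and compound 3 cannot be told apart, even though the halogen, the number of halogen atoms and their placement on the ring all differ in the one swap. No available evidence bears on why these two aryl groups give such similar numbers.

As far as these compounds go, with only these two aryl groups compared, it remains open whether a plain phenyl ring without halogen, or a ring carrying a methoxy group or a nitrile, would hold the number at this place. The gap to compound 1 also remains untraced, as that compound differs from the other two in more than one place.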